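Pyridyl swap on the unsubstituted core of compound 1

A few compounds are considered here, and "the series" means these few. Any claim that something is new, unique, unknown or untested is made for them only; others in the source may bear on it.

Compound 1 `CN(C)c1ccc(C2CC(c3ccncc3)=NN2)cc1` is the reference point of this set. In a functional assay on the whole organism (strain Charles Foster albino) for inhibition, with Rattus norvegicus as the target, read by paw edema, with stated times of 30 min and 3 h, at a dose of 50 mg/kg by the oral route (a higher number here means more inhibition at the dose given (going by the name of the read-out), a lower number less inhibition), compound 1 gives 0%, the lowest of the three numbers shown. Compound 2 `COc1ccc(OC)c(C2CC(c3cccnc3)=NN2c2ccccc2)c1` gives 24% and compound 3 `CN(C)c1ccc(C2CC(c3ccncc3)=NN2c2ccccc2)cc1` gives 32%; these two lie within the scatter of each other, and both stand beyond the scatter above compound 1.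

Going by the values given here, the one step measured in a single place is a number 32 percentage points higher from compound 1 to compound 3 (beyond the scatter), which concerns the ring nitrogen and not the pyridyl group. Compound 4 `CN(C)c1ccc(C2CC(c3cccnc3)=NN2)cc1` differs from compound 1 by pyridin-3-yl in place of pyridin-4-yl on a carbon with a double bond to nitrogen. Among the compounds with values here, compound 2 and compound 3 carry different pyridyl groups but also differ at the other aryl ring, so their values show only that both, with phenyl on the ring nitrogen, sit well above compound 1; no measured step isolates the pyridyl change. With nothing pointing beyond the scatter, the expected step is a number 5 percentage points higher from compound 1 to compound 4 (within the scatter), no change beyond the scatter. Compound 4 is therefore estimated at 5%, within 0% to 20%.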

Compound 4, a percentage reported as inhibition, in the whole organism at one dose (the size of the read-out at that dose, not a potency): 22%
The estimate for compound 4 lay 17 percentage points below the measured number, outside the stated range (above it).
By their numbers in this assay, from the lowest: compound 1; then compounds 4, 2 and 3 (each within the scatter of the next).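

In this assay, the carbon with a double bond to nitrogen proves sensitive to which pyridyl group it carries: with the same atoms joined differently, the swap to pyridin-3-yl gives a number 22 percentage points higher from compound 1 to compound 4 (beyond the scatter) on the unchanged core. A rise beyond the scatter from compound 1 therefore does not require phenyl on the ring nitrogen, the change that gave a number 32 percentage points higher from compound 1 to compound 3 (beyond the scatter) in the other single-place step. Nothing available explains the effect of the pyridyl swap.

Whether pyridin-3-yl in place of pyridin-4-yl has the same effect when phenyl sits on the ring nitrogen remains open, as no pair of compounds shown isolates that change. From the compounds shown here alone, the reading with pyridin-2-yl on this carbon also remains open.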